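Ethoxycarbonyl in place of carboxy on a stable core

The source may report more compounds than this note shows. Statements on the series, on what has been measured and on what is new or still open speak of the compounds shown alone.

Values in a physicochemical assay for metabolic stability, read by LC-MS, in phosphate buffer, with a stated time of 3 h, at pH 7.4, tested at 50 uM; a higher number here means that more of the compound is left, a lower number that less of the compound is left:
compound 1 `CC(C)OC(=O)c1cccc(NC(=O)[C@@H]2C[C@H](SC3=C(C(=O)O)N4C(=O)[C@H]([C@@H](C)O)[C@H]4[C@H]3C)CN2)c1` gives > 95%, a limit of the assay
compound 2 `CCOC(=O)C1=C(S[C@@H]2CN[C@H](C(=O)Nc3cccc(C(=O)OCC)c3)C2)[C@H](C)[C@@H]2[C@@H]([C@@H](C)OC(=O)CC)C(=O)N12` gives > 95%, a limit of the assay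
compound 3 `CCOC(=O)c1cccc(NC(=O)[C@@H]2C[C@H](SC3=C(C(=O)O)N4C(=O)[C@H]([C@@H](C)O)[C@H]4[C@H]3C)CN2)c1` gives > 95%, a limit of the assay

Compound 3 stands at the limit of this assay, and it shares that position with every other value shown: the limit of > 95% in this assay, at which 3 of the 3 values shown sit. Among the measured compounds shown here, the only step between measured compounds that differ in one place, hydrogen in place of methyl on a saturated chain carbon bound to an oxygen next to a carbonyl group and a saturated chain carbon, is a step that the two limits leave unreadable from compound 1 to compound 3. Compound 4 `CCOC(=O)C1=C(S[C@@H]2CN[C@H](C(=O)Nc3cccc(C(=O)OCC)c3)C2)[C@H](C)[C@@H]2[C@@H]([C@@H](C)O)C(=O)N12` differs from compound 3 by ethyl in place of hydrogen on an oxygen next to a carbonyl group. For the measured compounds named here, no measured step reads a size for a change of this kind, so nothing in the data argues for a step beyond the scatter in either direction. Compound 2, which carries ethoxycarbonyl on the same core as compound 4, sits at the limit of the assay. The step from compound 3 to compound 4 is therefore expected to be a step that the limit leaves unreadable from compound 3 to compound 4. Compound 4 is estimated at 96%, between 88% and 100%, most likely reported as a limit.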

Compound 4, percent of the compound remaining: > 95%
Compound 4: a limit, no number; the forecaster's own chance of this, stated with the estimate: 0.8%; the middle value does not contradict the limit.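

No new step can be read between compound 4 and either compound 2 or compound 3, as all of them sit at the same limit: the limit of > 95% in this assay, at which 4 of the 4 values shown sit.

The compounds shown leave open how far any of these changes moves the percent of compound remaining in this assay.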